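The compounds below may be only part of what the source reports. "The series", "measured", "known", "first", "only" and "open" are said of these compounds alone.

Measured in a functional assay on MDA-MB-231 cells (Homo sapiens) for cytotoxicity, read by MTT assay, with a stated time of 24 h; on this read-out higher numbers stand for weaker inhibition and lower numbers for stronger inhibition:
- compound 1 `Cc1cccc(-c2nc3cccnc3n2C2CCCC2)c1Cl`: 646 nM
- compound 2 `O=C(NC1CC1)c1ccc(-c2nc3cccnc3n2C2CCCC2)cc1`: 115 nM
- compound 3 `c1cnc2c(c1)nc(-c1cncnc1)n2C1CCCC1`: > 10000 nM

Compound 2 gives 115 nM, the lower of the two true numbers in this small set. Compound 1 gives 646 nM, and this gap to compound 2 lies beyond the usual scatter of repeated measurements. Compound 3 gives > 10000 nM, which is a limit of the assay and not a number.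

Compound 4 `c1cncc(-c2ccc(-c3nc4cccnc4n3C3CCCC3)cc2)c1` has not yet been measured in this assay. It keeps the core of compound 2 but carries pyridin-3-yl in place of cyclopropylcarbamoyl on an aromatic carbon, para to a large group (pyridin-3-yl in place of cyclopropylcarbamoyl on an aromatic carbon). Within the data shown here, no measured pair of compounds shows this swap on its own, so any forecast is rough. Compound 1 also lacks the cyclopropylcarbamoyl and gives 646 nM, which makes a higher number seem more likely than a lower one. A moderate change is expected, a 2.6-fold higher number from compound 2 to compound 4 (0.42 log units; beyond the scatter), towards weaker inhibition. For compound 4 the estimated value is 300 nM, with an expected range from 70 nM to 1800 nM.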

Compound 4, half-maximal inhibitory concentration: > 10000 nM
Compound 4 was reported as a limit; the forecaster's own chance of this, stated with the estimate: 8%; middle value at least 33-fold (1.52 log units) away from the limit.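

In this assay, putting pyridin-3-yl in place of cyclopropylcarbamoyl on an aromatic carbon, para to a large group, gives an at least 86-fold higher number from compound 2 to compound 4 (1.93 log units; beyond the scatter), a large step that shows this position is far from indifferent to what sits on it, even though both groups hold 6 heavy atoms and each brings one six-atom-sized substituent of similar bulk by count. Compound 4 gives > 10000 nM, which is a limit of the assay and not a number. The step can therefore be read only as a minimum, and compound 4 now shares its limit with compound 3: the limit of > 10000 nM in this assay, at which 2 of the 4 values shown sit.

What the compounds shown leave open is which part of the change matters: the leaving group carries a hydrogen-bond donor and a three-membered ring, while the entering group has no donor and brings an aromatic ring with a nitrogen. A simple methyl amide, a carboxylic acid or a plain phenyl group on the same carbon would help to separate these features, and the present compounds cannot say how such groups would behave.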